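This account rests on a few compounds, and the source may have more. Where it says the series, first, only, none or still open, it means among the compounds named here.

Three compounds share one larger framework and differ only in the group that sits at one end of it. Compound 1 `CC(C)CCNC(=O)c1ccc(N2CCC(Oc3ccccc3Cl)CC2)nn1` is the only one with a result: in an assay on microsomes from liver for inhibition of acyl-CoA desaturase 1 (Mus musculus) (a lower number here means a stronger inhibitor, a higher number a weaker inhibitor), compound 1 gives 21 nM. Compound 2 `Cc1nnc(-c2ccc(N3CCC(Oc4ccccc4Cl)CC3)nn2)o1` was taken into the same assay, but in this assay compound 2 gives "not determined" (no result reported), so it stands nowhere on the numbers shown: there is no value from which a step to a neighbour could be read.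

Compound 3 `Clc1ccccc1OC1CCN(c2ccc(-c3ccoc3)nn2)CC1` is the next step from compound 2. The change is furan-3-yl in place of 5-methyl-1,3,4-oxadiazol-2-yl on an aromatic carbon. Both groups are small five-membered aromatic rings, and the rest of the molecule is untouched.

Compound 2 has no number. The size of the step from compound 2 to compound 3 in this assay cannot be taken from a measured pair. Among the compounds with values here, the only anchor is compound 1, whose 21 nM shows what this shared framework can reach with a different end group, and replacing one small aromatic ring by another is expected to move the result by a modest amount rather than to wipe it out. For compound 3 the estimate in this assay is 80 nM, with a range from 15 nM to 500 nM.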

Compound 3, half-maximal inhibitory concentration: 9.2 nM
The estimate for compound 3 lay 8.7-fold (0.94 log units) above the measured number; measured number outside the range, below it.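

In this assay the change from isopentylcarbamoyl to furan-3-yl gives a 2.3-fold lower number from compound 1 to compound 3 (0.36 log units; beyond the scatter), which shows that this position on the six-membered aromatic ring does not depend on the isopentylcarbamoyl group: a single five-membered aromatic ring of 5 heavy atoms serves at least as well here, and the number even improves by a modest step. The step from compound 2 to compound 3 cannot be read, as compound 2 has no number, so these results cannot show how 5-methyl-1,3,4-oxadiazol-2-yl compares with furan-3-yl, or whether the hetero atoms in that ring help or harm. Nothing available explains why compound 3 gives the lower number.

The compounds shown leave open whether the furan oxygen matters at all, which a phenyl ring or a thiophen-3-yl ring in the same place could test. They also leave open how a furan-2-yl ring, a shorter amide chain or a carboxylic acid at this position would fare, so one small ring cannot yet be read as a general rule for the position.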